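Stomach inhibition series: amino in place of methyl

The compounds below may be only part of what the source reports. "The series", "measured", "known", "first", "only" and "open" are said of these compounds alone.

Measured so far:
compound 1, `Cc1nc2c(/C=C\c3ccccc3)cccn2c1C` — in a functional assay on the whole organism (stomach) for inhibition, with Canis familiaris (Canis lupus familiaris) as the target, at a dose of 4 mg/kg by the oral route (on this read-out higher numbers stand for a stronger effect at the one dose given and lower numbers for a weaker effect), compound 1 gives 37%
compound 2, `Cc1nc2c(/C=C\Cc3ccccc3)cccn2c1C` — in this assay compound 2 gives 13%

Compound 2 stands lowest of the two numbers. Its nearest neighbour is compound 1, which lies higher by a gap beyond the scatter. For the measured compounds named here, compound 1 and compound 2 differ in more than one place, so no single step between measured compounds is available to calibrate any change.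

Compound 3, `Cc1nc2c(/C=C\Cc3ccccc3)cccn2c1N`, has not yet been measured in this assay. Relative to compound 2 the change is: amino in place of methyl on an aromatic carbon.

Going by the values given here, with no measured step of this kind to lean on, the direction of the change cannot be read from the data. The step is expected to be small, no larger than the scatter, as a number 5 percentage points higher from compound 2 to compound 3 (within the scatter). Compound 3 is estimated at 18%, within a range from 3% to 42%.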

Compound 3, a percentage reported as inhibition, in the whole organism at one dose (the size of the read-out at that dose, not a potency): 0%
For compound 3 the middle estimate is 18 percentage points above the measured one; measured number outside the range, below it.
By their numbers in this assay, from the lowest: compound 3; then compound 2; then compound 1.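

In this assay the series now has its first step that changes one place: amino in place of methyl on an aromatic carbon of the five-membered aromatic ring gives a number 13 percentage points lower from compound 2 to compound 3 (beyond the scatter), and compound 3 gives 0% at the one dose tested. The methyl at this position, next to the ring nitrogen, therefore cannot be exchanged for amino without a loss beyond the scatter, at least on the core of compound 2. No measured property available here bears on this drop.

As far as these compounds go, it remains open whether the loss is specific to amino or would also follow from other replacements of this methyl, such as ethyl, methoxy or chloro. Also open, from the compounds shown here alone, is whether the same exchange would lower the number on the core of compound 1.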